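Aryl Back in Place of Butyl: What Compound 4 Might Show

This account rests on a few compounds, and the source may have more. Where it says the series, first, only, none or still open, it means among the compounds named here.

Three compounds have been measured in an ADME assay on PANC-1 cells (Homo sapiens) for cytotoxicity, read by sulforhodamine B assay, with a stated time of 48 h, tested at 10 uM; on this read-out higher numbers stand for more inhibition at the one concentration tested (going by the name of the read-out) and lower numbers for less inhibition:

Compound 1 `COc1nc2ccc(Br)cc2cc1C(c1ccccc1)n1cc(-c2ccc(Br)cc2)nn1` gives 10.4%
Compound 2 `CCCCc1cn(C(c2ccccc2)c2cc3cc(Br)ccc3nc2OC)nn1` gives 5.46%
Compound 3 `COc1nc2ccc(Br)cc2cc1C(c1ccccc1)n1cc(CCCO)nn1` gives 25.5%

Compound 2 stands lowest of these three numbers. Its nearest neighbour is compound 1: the step of a number 4.9 percentage points lower from compound 1 to compound 2 (within the scatter) lies within the scatter, so the two cannot be told apart. Its furthest neighbour is compound 3, reached by the step of a number 20 percentage points higher from compound 2 to compound 3 (beyond the scatter), and compound 3 also stands apart from compound 1 by a number 15.1 percentage points higher from compound 1 to compound 3 (beyond the scatter).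

Compound 4 `COc1nc2ccc(Br)cc2cc1C(c1ccccc1)n1cc(-c2ccc(OC(F)(F)F)cc2)nn1` has not yet been measured. It differs from compound 2 in one place: 4-(trifluoromethoxy)phenyl in place of butyl on an aromatic carbon. Within the data shown here, the only measured step that bears on this change is the one from compound 1 to compound 2, where the butyl of compound 2 took the place of an aryl group and the number moved by a number 4.9 percentage points lower from compound 1 to compound 2 (within the scatter), within the scatter. Compound 4 puts an aryl group back in that place, so the reverse of that step is the best guide; the steps involving compound 3 concern the 3-hydroxypropyl and do not bear on it.

The step from compound 2 to compound 4 in this assay is therefore expected to be small, if anything upward, around a number 5.5 percentage points higher from compound 2 to compound 4 (within the scatter). Compound 4 is expected to give about 11%, in a range from 0% to 24%.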

Compound 4, a percentage reported as inhibition, at one concentration (the size of the read-out at that concentration, not a potency): 11.7%
The estimate for compound 4 lay 0.7 percentage points below the measured number, within the range that was stated.
By their numbers in this assay, from the lowest: compounds 2, 1 and 4 (each within the scatter of the next); then compound 3.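

In this assay, the step of a number 6.2 percentage points higher from compound 2 to compound 4 (within the scatter) shows that this place on the ring, next to the ring nitrogen, takes 4-(trifluoromethoxy)phenyl, with its 11 heavy atoms, in place of butyl, with its 4, without a difference beyond the scatter, and the step of a number 1.3 percentage points higher from compound 1 to compound 4 (within the scatter) shows the same for trifluoromethoxy in place of bromo on the phenyl ring that sits there. Set against these, the step of a number 13.8 percentage points lower from compound 3 to compound 4 (beyond the scatter) leaves compound 3 as the only one of the four that stands apart from all the others, so the two aryl groups and butyl cannot be told apart here, while 3-hydroxypropyl can. Nothing available accounts for these numbers.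

The compounds shown leave open whether the hydroxy group itself goes with the number of compound 3, since no amine or carboxylic acid at the end of that chain appears among them, and neither does a longer chain ending in hydroxy. They also leave open whether a hydroxy group on the phenyl ring of the aryl compounds would bring the same separation from compound 1 and compound 4.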